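The source may report more compounds than this note shows. Statements on the series, on what has been measured and on what is new or still open speak of the compounds shown alone.

Compound 3 `Clc1ccc(C(Oc2ccc3cc(Br)ccc3c2)c2cnc(NCC3CCOCC3)s2)cc1` carries a 4-chlorophenyl group and a 6-bromonaphthalen-2-yl ether on the same saturated carbon, with a ((oxan-4-yl)methyl)amino group on its core. In an ADME assay on HepG2 2.2.15 cells (Homo sapiens) for cytotoxicity (on this read-out lower numbers stand for higher toxicity in this test and higher numbers for lower toxicity in this test), compound 3 is reported only in words, as "not toxic" (no number reported), without a number. Two related compounds give the same picture. Compound 1 `CC(C)(C)OC(=O)Nc1ncc(C(Oc2ccc(Br)cc2)c2ccc(Cl)cc2)s1`, with a 4-bromophenyl ether and a tert-butyl carbamate on the core, shows in this assay only the limit > 50000 nM. Compound 2 `Cc1cc(Br)cc(OC(c2ccc(Cl)cc2)c2cnc(NC(=O)OC(C)(C)C)s2)c1`, with a 3-bromo-5-methylphenyl ether, likewise shows only the limit > 50000 nM in this assay. The step that the two limits leave unreadable from compound 1 to compound 2 is therefore unreadable; both values sit at the limit of > 50000 nM in this assay, at which 2 of the 3 values shown sit.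

Compound 4 `O=S(=O)(Nc1ncc(C(Oc2ccc3cc(Br)ccc3c2)c2ccc(Cl)cc2)s1)c1ccc(Cl)nc1` differs from compound 3 by (6-chloropyridin-3-yl)sulfonyl in place of (oxan-4-yl)methyl on a nitrogen on an aromatic ring. Going by the values given here, no measured step covers an exchange on this nitrogen, so the only guide is that none of the three compounds in this assay showed toxicity within the measured range. On that basis compound 4 is expected to sit in this assay near 50000 nM, with a range of 20000 nM to 100000 nM, most likely again as a limit rather than a number.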

Compound 4, half-maximal cytotoxic concentration: "not toxic" (no number reported)
The entry for compound 4 holds no number, so the estimate cannot be set against anything.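

In this assay, going by these compounds alone, compound 4 is reported only in words, as is compound 3, so no step from compound 3 to compound 4 can be read. The compounds shown leave open whether any change on the shared core would give a measurable half-maximal cytotoxic concentration, and at what level: the limit of > 50000 nM in this assay, at which 2 of the 4 values shown sit.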